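Sulfonyl aryl substituent series: nitro to tert-butyl

The compounds below may be only part of what the source reports. "The series", "measured", "known", "first", "only" and "open" are said of these compounds alone.

Measured in a functional assay on HepG2 cells (Homo sapiens) for antiproliferative activity, read by MTT assay, with a stated time of 48 h; a lower number here means a stronger inhibitor, a higher number a weaker inhibitor:
- compound 1 , `O=C(/C=C/c1cn(S(=O)(=O)c2ccc([N+](=O)[O-])cc2)c2ccccc12)c1ccncc1`, gives 18300 nM
- compound 2 , `Cc1ccc(S(=O)(=O)n2cc(/C=C/C(=O)c3ccncc3)c3ccccc32)cc1`, gives 44800 nM
- compound 3 , `O=C(/C=C/c1cn(S(=O)(=O)c2ccc(Cl)cc2)c2ccccc12)c1ccncc1`, gives 35100 nM

Compound 1 has the lowest number of the three. Its nearest neighbour is compound 3, the step being a 1.9-fold higher number from compound 1 to compound 3 (0.28 log units; within the scatter); the furthest is compound 2, with a 2.4-fold higher number from compound 1 to compound 2 (0.39 log units; beyond the scatter).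

Compound 4, `CC(C)(C)c1ccc(S(=O)(=O)n2cc(/C=C/C(=O)c3ccncc3)c3ccccc32)cc1`, differs from compound 1 by tert-butyl in place of nitro on an aromatic carbon.

Both measured steps away from compound 1 bear on this change, since each also replaces the nitro on that aromatic carbon: one lies within the scatter, one modestly beyond it, and both go upward. A step of similar size in the same direction is therefore expected for compound 4 in this assay, namely a 2.3-fold higher number from compound 1 to compound 4 (0.36 log units; beyond the scatter). Compound 4 is estimated at 42000 nM, within a range of 18000 nM to 100000 nM.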

Compound 4, half-maximal inhibitory concentration: 27000 nM
For compound 4 the middle estimate is 1.6-fold (0.19 log units) above the measured one; the range from low to high includes it.
By their numbers in this assay, from the lowest: compounds 1, 4, 3 and 2 (each within the scatter of the next, the first and the last beyond it).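

In this assay, tert-butyl on this aromatic carbon cannot be told apart from nitro (a 1.5-fold higher number from compound 1 to compound 4 (0.17 log units; within the scatter)). Going by these compounds alone, it also cannot be told apart from chloro (a 1.3-fold lower number from compound 3 to compound 4 (0.11 log units; within the scatter)) or methyl (a 1.7-fold lower number from compound 2 to compound 4 (0.22 log units; within the scatter)), so the only step beyond the scatter in this set remains the one between nitro and methyl (a 2.4-fold higher number from compound 1 to compound 2 (0.39 log units; beyond the scatter)). No supporting data bear on this result. On these data alone, whether an amine, a carboxylic acid or a longer alkyl chain at this place would separate from these four groups remains open.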